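Cytotoxicity notes: hexylsulfanyl in place of 2-methoxyethoxy

The compounds below may be only part of what the source reports. "The series", "measured", "known", "first", "only" and "open" are said of these compounds alone.

Compound 1 `COCCOc1nc(N)nc2c1ncn2/C=C1/CC1(CO)CO` is the reference point of this set. In an ADME assay on BCBL1 cells (Homo sapiens) for cytotoxicity, with a stated time of 7 days (on this read-out higher numbers stand for lower toxicity in this test and lower numbers for higher toxicity in this test), compound 1 gives only a limit of the assay, > 20000 nM. Compound 2 `Nc1nc(OCc2ccccc2)c2ncn(/C=C3/CC3(CO)CO)c2n1` likewise gives only a limit in this assay, > 20000 nM. Compound 3 `CC(C)CNc1nc(N)nc2c1ncn2/C=C1/CC1(CO)CO` also gives only a limit in this assay, > 20000 nM. The three steps that connect them, a step that the two limits leave unreadable from compound 1 to compound 2, a step that the two limits leave unreadable from compound 1 to compound 3 and a step that the two limits leave unreadable from compound 2 to compound 3, cannot be sized because of the limit of > 20000 nM in this assay, at which 3 of the 3 values shown sit.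

Compound 4 `CCCCCCSc1nc(N)nc2c1ncn2/C=C1/CC1(CO)CO` is the next compound to be measured. It differs from compound 1 as follows: hexylsulfanyl in place of 2-methoxyethoxy on an aromatic carbon. The measured steps that bear on this change are those that also exchange the group on an aromatic carbon of the shared core, from compound 1 to compound 3 and from compound 2 to compound 3, and neither gives a readable size or direction. No step beyond the scatter in this assay can therefore be expected from the numbers shown; the working assumption is that compound 4 again sits at the limit. Compound 4 is therefore expected to give about 25000 nM in this assay, within 10000 nM to 60000 nM. The step that the limit leaves unreadable from compound 1 to compound 4 that this estimate implies is expected to be none beyond the scatter.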

Compound 4, half-maximal cytotoxic concentration: > 20000 nM
Compound 4 ended at the assay's limit; the forecaster's own chance of this, stated with the estimate: 80%; the middle value is on the limit's open side.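

No step between compound 4 and compound 1, compound 2 or compound 3 can be read in this assay, because each of these compounds gives only a limit: the limit of > 20000 nM in this assay, at which 4 of the 4 values shown sit.

The compounds shown leave open whether exchanging the group on this aromatic carbon of the shared core changes the cytotoxic concentration at all, and in which direction.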